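This account rests on a few compounds, and the source may have more. Where it says the series, first, only, none or still open, it means among the compounds named here.

Measured so far:
compound 1, `COc1cc2c(Oc3ccc(NC(=O)c4nn(-c5ccc(F)cc5)c(=O)c5ccccc45)cc3F)ccnc2cc1OCCCN1CCN(C)CC1`, in a functional assay on HT-29 cells (Homo sapiens) for cytotoxicity, read by MTT assay, with a stated time of 72 h; a higher number here means a weaker inhibitor, a lower number a stronger inhibitor: 320 nM
compound 2, `COc1cc2c(Oc3ccc(NC(=O)c4nn(-c5ccccc5Br)c(=O)c5ccccc45)cc3F)ccnc2cc1OCCCN1CCN(C)CC1`, in this assay: 1190 nM

Compound 2 gives the highest of the two numbers; its nearest neighbour is compound 1, and the step of a 3.7-fold higher number from compound 1 to compound 2 (0.57 log units; beyond the scatter) lies beyond the scatter. Compound 3 is `COc1cc2c(Oc3ccc(NC(=O)c4nn(-c5ccc([N+](=O)[O-])cc5)c(=O)c5ccccc45)cc3F)ccnc2cc1OCCCN1CCN(C)CC1`. It differs from compound 2 in one place: 4-nitrophenyl in place of 2-bromophenyl on an aromatic nitrogen.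

Going by the values given here, only one measured step bears on this change, and only in part. The step of a 3.7-fold higher number from compound 1 to compound 2 (0.57 log units; beyond the scatter) shows that moving from a 4-fluorophenyl to a 2-bromophenyl on the aromatic nitrogen raised the number by a modest amount. Among the compounds with values here, compound 3 returns to a phenyl carrying its substituent in the 4-position, as in compound 1, though the substituent is nitro rather than fluorine, and no measured pair shows what that exchange does on its own. The expectation is therefore a modest step downward, of about a 2.6-fold lower number from compound 2 to compound 3 (0.42 log units; beyond the scatter), landing near the number of compound 1 but with wide uncertainty. Compound 3 is estimated at 450 nM, within a range from 150 nM to 1400 nM.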

Compound 3, half-maximal inhibitory concentration: 2560 nM
For compound 3 the middle estimate is 5.7-fold (0.76 log units) below the measured one, and the stated range ends below it.
By their numbers in this assay, from the lowest: compound 1; then compound 2; then compound 3.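

Exchanging 2-bromophenyl for 4-nitrophenyl on the aromatic nitrogen gives a 2.2-fold higher number from compound 2 to compound 3 (0.33 log units; beyond the scatter) in this assay, so returning to a phenyl substituted at the 4-position does not by itself lower the number. Within that same substitution pattern, the 4-fluorophenyl of compound 1 and the 4-nitrophenyl of compound 3 are far from equivalent: nitro in place of fluoro gives an 8.0-fold higher number from compound 1 to compound 3 (0.90 log units; beyond the scatter), showing that the identity of the substituent matters here, not only where it sits on the phenyl ring. No measurement at hand accounts for the order of these three groups.

The compounds shown do not separate the effect of the substituent from the effect of its place on the ring, a question that a matched pair such as 4-bromophenyl and 2-bromophenyl, or 4-fluorophenyl and 2-fluorophenyl, could address. As far as these compounds go, it also remains open how an unsubstituted phenyl, a 4-aminophenyl or a 4-methoxyphenyl group would compare on the same aromatic nitrogen, and whether any of them would give a lower number than compound 1 does.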